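The compounds below may be only part of what the source reports. "The series", "measured", "known", "first", "only" and "open" are said of these compounds alone.

Measured compounds:
compound 1 `COc1ccc2c(=O)c(C(=O)NC3CCN(Cc4ccccc4)CC3)coc2c1`: 37.4%
compound 2 `O=C(NC1CCN(Cc2ccccc2)CC1)c1coc2cc(Br)ccc2c1=O`: 31.6%
compound 3 `COc1ccc2c(=O)c(C(=O)NCCC3CCN(Cc4ccccc4)CC3)coc2c1`: 32.4%

All three were tested in an assay on isolated protein for inhibition of Amine oxidase [flavin-containing] A (Homo sapiens), read by fluorescence and Amplex Red, with stated times of 15 min and 20 min, tested at 100 uM; a higher number here means more inhibition at the concentration tested (going by the name of the read-out), a lower number less inhibition. Compound 1 and compound 2 share a core and differ by bromo in place of methoxy on an aromatic carbon; the step of a number 5.8 percentage points lower from compound 1 to compound 2 (within the scatter) lies within the scatter. Compound 3 carries a longer chain to the amide than compound 1; the difference between the two cores is not broken down here, and the values of compound 3 and compound 1 sit within the scatter of each other.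

Compound 4 `O=C(NCCC1CCN(Cc2ccccc2)CC1)c1coc2cc(Br)ccc2c1=O` is not yet measured. It stands to compound 3 as compound 2 stands to compound 1: bromo in place of methoxy on an aromatic carbon. The place lines of the two changes agree word for word, so this is the same change. For compound 4 a step of a number 5.4 percentage points lower from compound 3 to compound 4 (within the scatter) is expected in this assay, resting on a number 5.8 percentage points lower from compound 1 to compound 2 (within the scatter) from the first pair. Compound 4 is thus estimated at 27%, with a range from 17% to 37%.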

Compound 4, a percentage reported as inhibition, at one concentration (the size of the read-out at that concentration, not a potency): 30.3%
For compound 4 the middle estimate is 3.3 percentage points below the measured one; the range from low to high includes it.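

In this assay bromo in place of methoxy on an aromatic carbon gives a number 2.1 percentage points lower from compound 3 to compound 4 (within the scatter) on the core with the longer chain to the amide, and the change reads alike on both cores: the same change on two cores in this assay, a number 5.8 percentage points lower (within the scatter) from compound 1 to compound 2 and a number 2.1 percentage points lower (within the scatter) from compound 3 to compound 4, 3.7 percentage points apart, within the scatter of two such steps

For the compounds shown here, both steps are small enough to stay within the scatter, so the agreement shows only that the change has no readable effect on either core. It does not show that a larger step would carry across in the same way, and readings at one concentration say nothing about potency.

Open, on these data alone, is whether another group on this aromatic carbon, such as an amine or a carboxylic acid, would give a step beyond the scatter. Also open, as far as these compounds go, is whether the same change behaves alike on a core with a still longer chain to the amide.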